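Benzamide variation on a shared triazolopyridine-bearing aniline core

The compounds below may be only part of what the source reports. "The series", "measured", "known", "first", "only" and "open" are said of these compounds alone.

Measured so far in a functional assay on U-251 cells (Homo sapiens) for antiproliferative activity, read by MTT assay, with a stated time of 72 h; a lower number here means a stronger inhibitor, a higher number a weaker inhibitor:
- compound 1 `O=C(Nc1ccc(Cl)c(-c2nnc3c(Cl)cccn23)c1)c1ccc(C(F)(F)F)cc1F`: compound 1 gives > 100000 nM, a limit of the assay and not a number.
- compound 2 `CS(=O)(=O)c1ccc(C(=O)Nc2ccc(Cl)c(-c3nnc4c(Cl)cccn34)c2)c(Cl)c1`: compound 2 gives 44600 nM.
- compound 3 `O=C(Nc1ccc(Cl)c(-c2nnc3c(Cl)cccn23)c1)c1c(F)cccc1Cl`: compound 3 gives > 100000 nM, again a limit and not a number.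

Compound 3 therefore stands at the upper edge of what this assay reports; only compound 2 gives an actual number, and two of the three values sit at the limit of > 100000 nM in this assay, at which 2 of the 3 values shown sit. Among the compounds with values here, no step between measured compounds changes a single place, so nothing measured anchors the move to compound 4 `Cc1cc(Cl)ccc1C(=O)Nc1ccc(Cl)c(-c2nnc3c(Cl)cccn23)c1`, which differs from compound 3 by 4-chloro-2-methylphenyl in place of 2-chloro-6-fluorophenyl on a carbonyl carbon. Given that compound 3 shows > 100000 nM, the step from compound 3 to compound 4 is expected to be small or none beyond the scatter, with an at least 1.1-fold lower number from compound 3 to compound 4 (0.04 log units; that floor lies within the scatter). Compound 4 is estimated at 90000 nM, between 30000 nM and 300000 nM, with a fair chance that only a limit is reported.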

Compound 4, half-maximal inhibitory concentration: > 100000 nM
Compound 4: a limit, no number; the forecaster's own chance of this, stated with the estimate: 55%; middle value at least 1.1-fold (0.04 log units) from the limit.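

In this assay, within the data shown here, compound 3 and compound 4 each give only a limit, so no step between them can be read: the limit of > 100000 nM in this assay, at which 3 of the 4 values shown sit. On these data alone, whether 4-chloro-2-methylphenyl in place of 2-chloro-6-fluorophenyl changes activity at all stays open.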